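Lengthening the amide side chain of compound 1

A few compounds are considered here, and "the series" means these few. Any claim that something is new, unique, unknown or untested is made for them only; others in the source may bear on it.

Values so far in a functional assay on MCF-10A cells (Homo sapiens) for inhibition (a higher number here means a weaker inhibitor, a lower number a stronger inhibitor), for the series:
- compound 1 `CCCCCCNC(=O)c1cc(NCc2cc(O)ccc2O)ccc1O` gives 14000 nM
- compound 2 `O=C(NCc1ccccc1)c1cc(NCc2cc(O)ccc2O)ccc1O` gives 17000 nM

Among the compounds with values here, compound 1 stands level with compound 2, the only other measured compound, and the two values lie within the scatter of each other. The next compound to read is compound 3 `CCCCCCCCCCCCNC(=O)c1cc(NCc2cc(O)ccc2O)ccc1O` and its change from compound 1 is hexyl in place of hydrogen on a saturated chain carbon, six bonds along the chain from an amide-type nitrogen with the shared core untouched. Within the data shown here, the only measured step of a 1.2-fold higher number from compound 1 to compound 2 (0.08 log units; within the scatter) is phenyl in place of pentyl on a saturated chain carbon bound to an amide-type nitrogen, and it stays within the scatter. That step alters the same side chain without extending it, so the data give no measured size for this change. A modest shift toward a lower number in this assay is expected, though only loosely, and a result within the scatter of compound 1 would not be surprising. The estimated move is a 1.6-fold lower number from compound 1 to compound 3 (0.19 log units; within the scatter) and it carries wide uncertainty. For compound 3 the expected value is 9000 nM within an estimated range of 2500 nM to 25000 nM.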

Compound 3, half-maximal inhibitory concentration: 3000 nM
For compound 3 the middle estimate is 3.0-fold (0.48 log units) above the measured one; the measured number falls inside the stated range.
By their numbers in this assay, from the lowest: compound 3; then compounds 1 and 2 (each within the scatter of the next).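

In this assay, within the data shown here, hexyl in place of hydrogen on a saturated chain carbon, six bonds along the chain from an amide-type nitrogen, gives a 4.7-fold lower number from compound 1 to compound 3 (0.67 log units; beyond the scatter), the first step to lie beyond the scatter. Among these compounds, the only earlier step, a 1.2-fold higher number from compound 1 to compound 2 (0.08 log units; within the scatter), stayed within the scatter, so it gave no sign that the number responds to changes in this side chain; the new step shows that it can, and that an addition of carbon alone, with no ring, no hydrogen-bond donors or acceptors and no net charge, is enough to produce a modest shift. No measurement at hand bears on the reason for this step.

Among the compounds shown here, with only two chain lengths on the same core, the step fixes no trend with length, and a longer chain could lower the number further, leave it level or raise it. Going by these compounds, whether the step needs an all-carbon chain also stays open, as a carboxylic acid or an amine at the far end of the chain would test.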